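A few compounds are considered here, and "the series" means these few. Any claim that something is new, unique, unknown or untested is made for them only; others in the source may bear on it.

Compound 1 `C=CCn1c(=O)/c(=C\c2cccc(Cl)c2)[nH]c(=O)/c1=C\c1ccccc1OC` gives 4500 nM in a functional assay on HL-60 cells (Homo sapiens) for cytotoxicity, read by CCK-8 assay, with a stated time of 72 h; on this read-out higher numbers stand for weaker inhibition and lower numbers for stronger inhibition.
Compound 2 `C=CCn1c(=O)/c(=C\c2cccc(F)c2)[nH]c(=O)/c1=C\c1ccccc1OC` gives 8890 nM in this assay.
Compound 3 `C=CCn1c(=O)/c(=C\c2cccc(Br)c2)[nH]c(=O)/c1=C\c1ccccc1OC` gives 5200 nM in this assay.

All three share one core and differ only in the group on one aromatic ring: chloro, fluoro or bromo. Compound 2 has the highest number of the three, but its gaps to the others, a 1.7-fold lower number from compound 2 to compound 3 (0.23 log units; within the scatter) and a 2.0-fold higher number from compound 1 to compound 2 (0.30 log units; within the scatter), both fall inside the scatter, so the three values cannot be told apart.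

Compound 4 `C=CCn1c(=O)/c(=C\c2cccc(C)c2)[nH]c(=O)/c1=C\c1ccccc1OC` arises from compound 2 by a single change: methyl in place of fluoro on an aromatic carbon. Among the compounds with values here, no measured step exchanges fluoro for methyl. The steps measured so far, a 2.0-fold higher number from compound 1 to compound 2 (0.30 log units; within the scatter), a 1.2-fold higher number from compound 1 to compound 3 (0.06 log units; within the scatter) and a 1.7-fold lower number from compound 2 to compound 3 (0.23 log units; within the scatter), exchange one of chloro, fluoro and bromo for another, and each stays within the scatter. On that basis the expected step in this assay is none beyond the scatter, in no particular direction, which is written as a 1.5-fold lower number from compound 2 to compound 4 (0.17 log units; within the scatter). Compound 4 is therefore estimated at 6000 nM, with a range from 2500 nM to 15000 nM.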

Compound 4, half-maximal inhibitory concentration: 16700 nM
Estimate against measurement, compound 4: 2.8-fold (0.44 log units) below; measured number above the stated range.
By their numbers in this assay, from the lowest: compounds 1, 3, 2 and 4 (each within the scatter of the next, the first and the last beyond it).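

Within the data shown here, at this position in this assay, methyl is the first exchange to produce steps beyond the scatter: a 3.2-fold higher number from compound 3 to compound 4 (0.51 log units; beyond the scatter) and a 3.7-fold higher number from compound 1 to compound 4 (0.57 log units; beyond the scatter) both mean weaker inhibition, though both are modest. The picture is not a clean split between halogens and methyl, and fluoro goes against it: a 1.9-fold higher number from compound 2 to compound 4 (0.27 log units; within the scatter) leaves compound 2 and compound 4 indistinguishable, even though compound 2 also cannot be told apart from compound 1 or compound 3. Nothing available explains why methyl separates from chloro and bromo but not from fluoro.

The compounds shown carry only chloro, fluoro, bromo and methyl here, so it remains open how an amine, a carboxylic acid or a longer chain such as ethyl would read at this position. Also open, on these data alone, is whether methyl in place of chloro or bromo would give a similar step on the other aromatic ring.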